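A few compounds are considered here, and "the series" means these few. Any claim that something is new, unique, unknown or untested is made for them only; others in the source may bear on it.

Compound 1, `CC(CCN(C)C)c1ccc2ccccc2c1`, has the lowest of the two numbers measured in an assay on membranes from brain for displacement of a labelled ligand from Sigma non-opioid intracellular receptor 1 (Cavia porcellus) (a lower number here means a stronger inhibitor, a higher number a weaker inhibitor), where compound 1 gives 1.95 nM. Its nearest neighbour is compound 2, `COc1ccc2cc(C(C)CCN(C)C)ccc2c1`, which carries methoxy in place of hydrogen on an aromatic carbon and in this assay gives 2.3 nM; the step from compound 1 to compound 2 is a 1.2-fold higher number from compound 1 to compound 2 (0.07 log units; within the scatter), so the two values stand within the scatter of each other.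

Compound 3, `CC(CCN(C)Cc1ccccc1)c1ccc2ccccc2c1`, differs from compound 1 by phenyl in place of hydrogen on a saturated chain carbon bound to an amine nitrogen; cut one bond further out, the same difference reads methyl to benzyl. Within the data shown here, the only measured step, from compound 1 to compound 2, concerns the aromatic part of the core and does not bear on a change at the amine nitrogen. Among the measured compounds shown here, no measured step therefore speaks to this change, and the expectation can rest only on compound 1 itself. Compound 3 is expected to sit close to compound 1, with an estimated step of a 1.3-fold higher number from compound 1 to compound 3 (0.11 log units; within the scatter), so that the estimate for compound 3 is 2.5 nM within a range from 0.5 nM to 12 nM.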

Compound 3, inhibition constant: 5.4 nM
Compound 3: the middle estimate sits 2.2-fold (0.33 log units) below what was measured; measured number inside the range.
By their numbers in this assay, from the lowest: compounds 1 and 2 (each within the scatter of the next); then compound 3.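

Among these compounds, at the amine nitrogen, on which the earlier compounds offered no step, the change from methyl to benzyl gives a 2.8-fold higher number from compound 1 to compound 3 (0.44 log units; beyond the scatter), so in this assay this position responds to the change, if only modestly. The size of the step also shows that the added phenyl is accommodated without a large rise in the number: compound 3 gives 5.4 nM. Nothing available here explains why this phenyl raises the number.

From the compounds shown here alone, it remains open whether an ethyl or a phenethyl group in place of benzyl on the amine nitrogen would bring the number closer to that of compound 1 or move it further away. Going by these compounds, it is also open whether methoxy on an aromatic carbon, whose step a 1.2-fold higher number from compound 1 to compound 2 (0.07 log units; within the scatter) stands alone, would remain within the scatter when benzyl is present.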